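Thiourea series: phenyl for quinolin-3-yl on compound 1

This account rests on a few compounds, and the source may have more. Where it says the series, first, only, none or still open, it means among the compounds named here.

Measured compounds:
compound 1 `FC(F)(F)c1cnc(N2CCC(NC(=S)Nc3cnc4ccccc4c3)CC2)c(Cl)c1`: 2%
compound 2 `FC(F)(F)c1cnc(NCCCNC(=S)Nc2cccnc2)c(Cl)c1`: 0%
compound 3 `CN(C(=S)Nc1cccnc1)C1CCN(c2ncc(C(F)(F)F)cc2Cl)CC1`: 61%

All three were tested in an assay on membranes from brain for binding affinity to Lysophosphatidylserine lipase ABHD12 (Mus musculus), read by fluorescence, with a stated time of 20 min, tested at 10 uM; on this read-out higher numbers stand for a stronger effect at the one concentration tested and lower numbers for a weaker effect. On the numbers shown, compound 1 stands second highest of three. Its nearest neighbour is compound 2, which lies within the scatter of it, so no order between compound 1 and compound 2 can be claimed. The furthest is compound 3, which lies well beyond the scatter above compound 1; compound 3 is the only one of the three with a clearly raised number in this assay.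

The next compound, compound 4 `FC(F)(F)c1cnc(N2CCC(NC(=S)Nc3ccccc3)CC2)c(Cl)c1`, differs from compound 1 in one place: phenyl in place of quinolin-3-yl on an amide-type nitrogen. For the measured compounds named here, no measured pair in the set shows this change, so no step for it is known. Compound 1 is close to the floor of the read-out, and the nearest analogue of the same shape, compound 2, is as well. Compound 4 is therefore expected to remain near the floor, with a step of a number 3 percentage points higher from compound 1 to compound 4 (within the scatter) in this assay that is expected to stay within the scatter. For compound 4 the estimate in this assay is 5%, with a range from -5% to 20%.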

Compound 4, a percentage reported as inhibition, at one concentration (the size of the read-out at that concentration, not a potency): 96%
For compound 4 the middle estimate is 91 percentage points below the measured one; measured number above the stated range.
By their numbers in this assay, from the lowest: compounds 2 and 1 (each within the scatter of the next); then compound 3; then compound 4.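

In this assay, the group on the amide-type nitrogen whose other neighbour is the thiocarbonyl carbon has a large effect on the shared core: phenyl in place of quinolin-3-yl gives a number 94 percentage points higher from compound 1 to compound 4 (beyond the scatter) and lifts the number out of the floor region. For the compounds shown here, the low number of compound 1 is therefore not a general feature of the shared core, a point the earlier compounds could not show, as they offered no pair differing in one place. No measured information accounts for the size of this step, and its cause remains unknown.

On these data alone, it remains open whether the step follows from losing the ring nitrogen or the second ring, which a naphthyl group on the same core would separate. As far as these compounds go, whether a methoxy group on the phenyl ring would keep the number of compound 4 also remains open.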